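The compounds below may be only part of what the source reports. "The series", "measured", "known", "first", "only" and "open" are said of these compounds alone.

Measured compounds:
- compound 1, `CCCN1C(=O)/C(=C\C(=O)C[C@@H]2O[C@H](COC(C)=O)[C@@H](OC(C)=O)[C@H](OC(C)=O)[C@H]2OC(C)=O)c2cc(Cl)ccc21`: 95600 nM
- compound 2, `CC(=O)OC[C@H]1O[C@@H](CC(=O)/C=C2\C(=O)N(Cc3ccc(Br)cc3)c3ccc(Cl)cc32)[C@H](OC(C)=O)[C@@H](OC(C)=O)[C@@H]1OC(C)=O`: 93300 nM

Both were tested in an ADME assay on Vero cells (Chlorocebus sabaeus) for cytotoxicity, read by resazurin assay, with a stated time of 72 h; a lower number here means that less compound is tolerated, a higher number that more compound is tolerated. Among the measured compounds shown here, on these two numbers compound 2 stands lowest, with compound 1 as its only neighbour; the gap between them is within the scatter, so the two values cannot be told apart. For the measured compounds named here, the one step available, a 1.0-fold lower number from compound 1 to compound 2 (0.01 log units; within the scatter), swaps the group on a saturated chain carbon bound to an amide-type nitrogen in a ring and leaves the read-out essentially unchanged.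

Compound 3, `CC(=O)OC[C@H]1O[C@@H](CC(=O)/C=C2\C(=O)N(Cc3cccc(C)c3)c3ccc(Cl)cc32)[C@H](OC(C)=O)[C@@H](OC(C)=O)[C@@H]1OC(C)=O`, is reached from compound 2 by a change at that same place: 3-methylphenyl in place of 4-bromophenyl on a saturated chain carbon bound to an amide-type nitrogen in a ring. Going by the values given here, the only measured step that bears on this position is the one from compound 1 to compound 2, and it stayed within the scatter. There is no basis here for a shift in either direction, so the step from compound 2 to compound 3 is expected to be a 1.0-fold lower number from compound 2 to compound 3 (0.02 log units; within the scatter), that is, no change beyond the scatter. Compound 3 is accordingly estimated at 90000 nM, with a range from 45000 nM to 180000 nM.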

Compound 3, half-maximal cytotoxic concentration: 91000 nM
Compound 3: middle estimate off by 1.0-fold (0.00 log units), on the low side; low and high end bracket the measured number.
By their numbers in this assay, from the lowest: compounds 3, 2 and 1 (each within the scatter of the next).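

Replacing 4-bromophenyl with 3-methylphenyl gives a 1.0-fold lower number from compound 2 to compound 3 (0.01 log units; within the scatter) in this assay, so a second exchange of one substituted phenyl group for another at this place also stays within the scatter. Comparing the ethyl of compound 1 with the 3-methylphenyl of compound 3 gives a 1.1-fold lower number from compound 1 to compound 3 (0.02 log units; within the scatter) and is also within the scatter, which means that the three compounds cannot be told apart in this cell test, whether the group at this place ends in a small chain or in a phenyl ring carrying either bromine or a methyl group. No accompanying measurement explains why the values stay so close together.

All the groups compared here are built from carbon and hydrogen, apart from the one bromine, so it remains open whether an amine or a carboxylic acid on a saturated chain carbon bound to an amide-type nitrogen in a ring would stay within the scatter of these compounds. The shared core also stays the same throughout, so these compounds cannot show whether replacing its acetate groups with free hydroxyl groups would matter in this cell test.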